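Shortening the acyl chain of compound 1

The source may report more compounds than this note shows. Statements on the series, on what has been measured and on what is new or still open speak of the compounds shown alone.

Three compounds of the series carry numbers in a functional assay on the whole organism for antagonist activity, with Mus musculus as the target; a higher number here means that more compound is needed for the effect, a lower number that less compound is needed. Compound 1 `CCCCC(=O)NCC(=O)N(C)c1ccc(Cl)cc1C(=O)c1ccccc1Cl` gives 1.3 mg/kg, the lowest of the three. Compound 2 `NCC(=O)NCC(=O)Nc1ccc([N+](=O)[O-])cc1C(=O)c1ccccc1` gives 4.82 mg/kg, and compound 3 `NCC(=O)NCC(=O)Nc1ccc([N+](=O)[O-])cc1C(=O)c1ccccc1Cl` gives 2.64 mg/kg. For the measured compounds named here, the only single-point step in the set, a 1.8-fold lower number from compound 2 to compound 3 (0.26 log units; within the scatter), concerns an aromatic substituent and lies within the scatter. Compound 1 stands apart from compound 3 and from compound 2 by more than the scatter, but it differs from both in several places at once, so no single change can be credited for its position.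

Compound 4 `CC(=O)NCC(=O)N(C)c1ccc(Cl)cc1C(=O)c1ccccc1Cl` differs from compound 1 in one place: hydrogen in place of propyl on a saturated chain carbon bound to a carbonyl carbon. Going by the values given here, no measured step addresses this kind of change; the single step of a 1.8-fold lower number from compound 2 to compound 3 (0.26 log units; within the scatter) sits on an aromatic carbon, and the acyl chain does not vary anywhere else in the set. The expectation therefore rests on compound 1 alone, with wide bounds. Compound 4 is estimated at 1.9 mg/kg, within 0.8 mg/kg to 4.5 mg/kg. The expected step is a 1.5-fold higher number from compound 1 to compound 4 (0.16 log units; within the scatter), with no direction confidently foreseen beyond the scatter.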

Compound 4, dose for half-maximal effect: 2.3 mg/kg
Estimate against measurement, compound 4: 1.2-fold (0.08 log units) below, and the stated range covers the measured number.
By their numbers in this assay, from the lowest: compounds 1, 4, 3 and 2 (each within the scatter of the next, the first and the last beyond it).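

In this assay, the acyl chain now has its first measured step, a 1.8-fold higher number from compound 1 to compound 4 (0.25 log units; within the scatter), with hydrogen in place of propyl on a saturated chain carbon bound to a carbonyl carbon. This step stays within the scatter, so the butylcarbonyl of compound 1 and the acetyl of compound 4 are not told apart, and the propyl can go without a shift that exceeds it. Nothing available bears on the reason for this result.

A chain longer than butyl, a carboxylic acid or a phenyl ring at this place remains untested in the compounds shown, so the limits of tolerance at this position are still unknown. On these data alone, the step is also known only on the core of compound 1, and whether it would read the same on the core of compound 3 stays open.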